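A few compounds are considered here, and "the series" means these few. Any claim that something is new, unique, unknown or untested is made for them only; others in the source may bear on it.

Compound 1 `COc1cc(-n2cnc3ccc(-c4ccc(C(F)(F)F)cc4)cc32)cc(OC)c1OC`: 3390 nM
Compound 2 `COc1cc(-n2cnc3ccc(-c4cccc(O)c4)cc32)cc(OC)c1OC`: 250 nM
Compound 3 `COc1cc(-n2cnc3ccc(-c4cccc(F)c4)cc32)cc(OC)c1OC`: 5270 nM

In a functional assay on A549 cells (Homo sapiens) for antiproliferative activity, read by MTT assay, with a stated time of 72 h (on this read-out higher numbers stand for weaker inhibition and lower numbers for stronger inhibition), compound 3 sits at the high end of these numbers. Its measured position shows a 1.6-fold higher number from compound 1 to compound 3 (0.19 log units; within the scatter), and also a 21-fold higher number from compound 2 to compound 3 (1.32 log units; beyond the scatter). Compound 4 `COc1cc(-n2cnc3ccc(-c4ccc(Cl)cc4Cl)cc32)cc(OC)c1OC` carries 2,4-dichlorophenyl in place of 3-fluorophenyl on an aromatic carbon. The closest guide is the exchange of one halogen-bearing group for another, which gave a 1.6-fold higher number from compound 1 to compound 3 (0.19 log units; within the scatter). The large steps in this small set both involve the hydroxy group of compound 2, as in a 14-fold lower number from compound 1 to compound 2 (1.13 log units; beyond the scatter). Compound 4 has no hydroxy group, so those large steps do not carry over to it directly. Among the measured compounds shown here, no measured compound carries the 2,4-dichlorophenyl group, which leaves the estimate loose. No change beyond the scatter is therefore expected in this assay, and the expected step is a 1.3-fold lower number from compound 3 to compound 4 (0.12 log units; within the scatter). For compound 4 the estimated value is 4000 nM, with an expected range from 1500 nM to 10000 nM.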

Compound 4, half-maximal inhibitory concentration: > 10000 nM
Compound 4 ended at the assay's limit (the forecaster's own chance of this, stated with the estimate: 10%); at least 2.5-fold (0.39 log units) between middle value and limit.
By their numbers in this assay, from the lowest: compound 2; then compounds 1 and 3 (each within the scatter of the next). At a limit, above all of these: compound 4.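

In this assay compound 4 stands at a limit and not at a number: the limit of > 10000 nM in this assay, at which 1 of the 4 values shown sits. The earlier compounds shown here had left compound 1 and compound 3 within the scatter of each other, so the groups without a hydroxy at this position could have seemed interchangeable, yet the 2,4-dichlorophenyl group gives an at least 2.9-fold higher number from compound 1 to compound 4 (0.46 log units; beyond the scatter). Going by these compounds, the distance from the hydroxy-bearing group also grows, with an at least 40-fold higher number from compound 2 to compound 4 (1.60 log units; beyond the scatter), while an at least 1.8-fold higher number from compound 3 to compound 4 (0.27 log units; that floor lies within the scatter) shows only a floor, so the size of the change from 3-fluorophenyl to 2,4-dichlorophenyl remains unknown.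

On these data alone, whether a single chlorine on the phenyl ring would have the same effect stays open. So does whether an amine or a carboxylic acid in place of the hydroxy of compound 2 would keep the low number of compound 2.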